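Methoxy for methyl on the aryl amide of compound 1

The source may report more compounds than this note shows. Statements on the series, on what has been measured and on what is new or still open speak of the compounds shown alone.

Measured so far:
- Compound 1 `COc1cccc(S(=O)(=O)Nc2n[nH]c3c2CCN(c2ccc(C)cc2)C3=O)c1`: 6770 nM
- Compound 2 `Cc1ccc(N2CCc3c(NS(=O)(=O)c4cccc(Cl)c4C)n[nH]c3C2=O)cc1`: 1660 nM

Compound 1 stands at the highest of the two numbers in a functional assay on HeLa cells for antagonist activity at 5-hydroxytryptamine receptor 6 (Homo sapiens), read by cAMP accumulation, with stated times of 10 min and 30 min; on this read-out higher numbers stand for weaker inhibition and lower numbers for stronger inhibition; compound 2 gives a lower number, and a 4.1-fold lower number from compound 1 to compound 2 (0.61 log units; beyond the scatter). That step changes the aryl group on the sulfonyl sulfur, a different place from the one now in question.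

Compound 3 `COc1ccc(N2CCc3c(NS(=O)(=O)c4cccc(OC)c4)n[nH]c3C2=O)cc1` has not yet been measured. It differs from compound 1 by methoxy in place of methyl on an aromatic carbon. No measured step touches this place, so nothing shown bears directly on the change, and the step from compound 1 to compound 2 is only a general sign that single-group swaps here can move the number modestly. Without a relevant precedent, the expectation is a step within the scatter, a 1.1-fold lower number from compound 1 to compound 3 (0.05 log units; within the scatter). Compound 3 is therefore estimated at 6000 nM, with a range from 2500 nM to 15000 nM.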

Compound 3, half-maximal inhibitory concentration: 7080 nM
Estimate against measurement, compound 3: 1.2-fold (0.07 log units) below; the measured number falls inside the stated range.
By their numbers in this assay, from the lowest: compound 2; then compounds 1 and 3 (each within the scatter of the next).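

Going from 4-methylphenyl to 4-methoxyphenyl gives the first reading at this position: in this assay the swap amounts to a 1.0-fold higher number from compound 1 to compound 3 (0.02 log units; within the scatter) and stays within the scatter, so compound 1 and compound 3 cannot be told apart. Going by these compounds alone, one extra oxygen, and with it one hydrogen-bond acceptor, therefore shows no measurable effect at this place, while the sulfonyl sulfur remains the only place where a step beyond the scatter has appeared, with a 4.1-fold lower number from compound 1 to compound 2 (0.61 log units; beyond the scatter) on record. Nothing measured here explains why these two groups read alike.

On these data alone, whether an amine or a carboxylic acid at this place would read differently remains open. So does whether methoxy and methyl would also read alike with the 3-chloro-2-methylphenyl group of compound 2 on the sulfonyl sulfur.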